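The source may report more compounds than this note shows. Statements on the series, on what has been measured and on what is new or still open speak of the compounds shown alone.

In a physicochemical assay for solubility, in phosphate buffer, at pH 7.4 (a lower number here means a less soluble compound, a higher number a more soluble compound), compound 1 (`CCOC(=O)c1c(-c2ccccc2C)[nH]c2cc(OC)ccc2c1=O`) reads > 100000 nM, which is a limit of the assay and not a number. Among the compounds with values here, compound 2 (`CCOC(=O)c1c(-c2ccccc2Cl)[nH]c2cc(OC)ccc2c1=O`) gives 28000 nM, the only true number so far. Within the data shown here, the single measured step is an at least 3.5-fold lower number from compound 1 to compound 2 (0.55 log units; beyond the scatter), with chloro in place of methyl on an aromatic carbon, and it lies beyond the scatter. Compound 3 (`CCOC(=O)c1c(-c2cccs2)[nH]c2cc(OC)ccc2c1=O`) has thiophen-2-yl in place of 2-chlorophenyl on an aromatic carbon, next to the ring nitrogen: thiophen-2-yl in place of 2-chlorophenyl on an aromatic carbon. Among the measured compounds shown here, no measured step exchanges the whole ring, so an at least 3.5-fold lower number from compound 1 to compound 2 (0.55 log units; beyond the scatter) is only a loose guide to size and gives no direction. A modest change in this assay is expected, leaning upward since compound 2 at 28000 nM holds the lower of the two readings. The expected change is a 1.4-fold higher number from compound 2 to compound 3 (0.15 log units; within the scatter). For compound 3 the estimate is 40000 nM, with an expected range of 13000 nM to 100000 nM.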

Compound 3, solubility: > 100000 nM
Compound 3 gave a limit, no number; the forecaster's own chance of this, stated with the estimate: 15%; middle value at least 2.5-fold (0.39 log units) away from the limit.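

In this assay, thiophen-2-yl in place of 2-chlorophenyl on this aromatic carbon gives an at least 3.5-fold higher number from compound 2 to compound 3 (0.55 log units; beyond the scatter), so exchanging the whole ring here also moves the reading beyond the scatter, and of the three compounds only compound 2, with its 2-chlorophenyl group, gives a true number. Compound 3 reads > 100000 nM, which is a limit of the assay and not a number. The step between compound 1 and compound 3 cannot be read, because both readings are limits: the limit of > 100000 nM in this assay, at which 2 of the 3 values shown sit.

From the compounds shown here alone, how far compound 3 lies from compound 2 remains open, as does whether compound 1 and compound 3 differ at all. Also open, going by these compounds, is whether an unsubstituted phenyl, or a phenyl carrying an amine or a carboxylic acid, at this position would give a true number, as compound 2 does.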